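The compounds below may be only part of what the source reports. "The series", "measured", "known", "first", "only" and "open" are said of these compounds alone.

Compound 1 `COc1cc(C2=NN(C(C)=O)C(c3c(Cl)cccc3Cl)O2)cc(OC)c1OC` gives 5.1% in a functional assay on PC-3 cells (Homo sapiens) for antiproliferative activity, read by MTT assay, tested at 1 uM (a lower number here means a weaker effect, a higher number a stronger effect of the compound at the concentration tested), the lower of the two numbers at hand; compound 2 `COc1cc(C(=O)N/N=C/c2cccc(F)c2)cc(OC)c1OC` gives 53.5% in this assay, a value beyond the scatter above it. Compound 3 `COc1cc(C2=NN(C(C)=O)C(c3ccc(C(F)(F)F)cc3)O2)cc(OC)c1OC` differs from compound 1 by 4-(trifluoromethyl)phenyl in place of 2,6-dichlorophenyl on a saturated ring carbon. Among the measured compounds shown here, no step between measured compounds tells how such an exchange plays out, and compound 2 has a different core, so its value offers no direct guide. Compound 3 is expected to stay weak, with a step of a number 6.9 percentage points higher from compound 1 to compound 3 (within the scatter) that need not go beyond the scatter. Compound 3 is estimated at 12%, within a range from 0% to 35%.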

Compound 3, a percentage reported as inhibition, at one concentration (the size of the read-out at that concentration, not a potency): -11%
Beside the measured number, compound 3's estimate is 23 percentage points above it; measured number below the stated range.
By their numbers in this assay, from the lowest: compound 3; then compound 1; then compound 2.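

In this assay, the group on the saturated ring carbon of the core of compound 1 can move the read-out: 4-(trifluoromethyl)phenyl in place of 2,6-dichlorophenyl gives a number 16.1 percentage points lower from compound 1 to compound 3 (beyond the scatter). This exchange therefore brings no gain at this position, and neither aryl group gives a strong effect on this core at the concentration tested. No measurement at hand gives a reason for this step.

As far as these compounds go, whether an amine or a carboxylic acid on this carbon would raise the read-out remains open. Also open, from the compounds shown here alone, is how a plain phenyl group would compare with either aryl group.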